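The source may hold more compounds than are shown below. What is called first, only, known or untested is meant among the compounds shown, and "the series" means these compounds.

In a functional assay on SK-OV-3 cells (Homo sapiens) for antiproliferative activity, read by MTT assay, with a stated time of 72 h (a higher number here means a weaker inhibitor, a lower number a stronger inhibitor), compound 1 `COc1cccc(-c2cccc(NC(=O)CCc3ccc4c(c3)COB4O)c2)c1` gives > 100000 nM, which is a limit of the assay and not a number. Compound 2 `COc1cc(OC)cc(-c2cccc(NC(=O)CCc3ccc4c(c3)COB4O)c2)c1` reads 93000 nM and compound 3 `CC(=O)c1ccc(-c2cccc(NC(=O)CCc3ccc4c(c3)COB4O)c2)cc1` reads 79000 nM. These two values lie within the scatter of each other, so compound 2 has no separate standing among the numbers: a 1.2-fold lower number from compound 2 to compound 3 (0.07 log units; within the scatter).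

Compound 4 `COc1cc(OC)cc(-c2cccc(NC(=O)CCc3ccccc3)c2)c1` differs from compound 2 by a group of 6 heavy atoms (6 carbon; one six-membered aromatic ring of carbon only) in place of a group of 10 heavy atoms (7 carbon, 1 boron, 2 oxygen; one five-membered non-aromatic ring with 2 hetero atoms, one six-membered aromatic ring of carbon only), on a saturated chain carbon, two bonds along the chain from a carbonyl carbon, so the boron leaves with that group. For the measured compounds named here, none of the measured steps changes this group. They bear on it only indirectly, as changes made elsewhere in the molecule: an at least 1.0-fold lower number from compound 1 to compound 2 (0.03 log units; that floor lies within the scatter), and an at least 1.2-fold lower number from compound 1 to compound 3 (0.10 log units; that floor lies within the scatter). Its effect is therefore unmeasured, and the weak reading of compound 2 at 93000 nM offers little basis for expecting a large change in either direction.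

No step beyond the scatter is expected in this assay, and the estimate is a 1.1-fold higher number from compound 2 to compound 4 (0.03 log units; within the scatter). A result reported only as a limit would not be surprising. For compound 4 the estimated value is 100000 nM, with an expected range of 60000 nM to 170000 nM.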

Compound 4, half-maximal inhibitory concentration: > 100000 nM
Compound 4: a limit, no number (the forecaster's own chance of this, stated with the estimate: 60%); the middle value sits exactly at the limit.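

The reading for compound 4 in this assay is a limit of the assay and not a number. This is the first change shown at the saturated chain carbon, two bonds along the chain from a carbonyl carbon, as the earlier steps all changed groups elsewhere in the molecule, and phenyl in place of the boron-bearing group gives an at least 1.0-fold higher number from compound 2 to compound 4 (0.03 log units; that floor lies within the scatter). Loss of the boron thus produces no step that can be told from the scatter, and any larger change stays hidden at the top of the readable range: the limit of > 100000 nM in this assay, at which 2 of the 4 values shown sit.

Whether the boron-bearing group contributes anything in this series remains open, with no compound shown reading well clear of the limit. As far as these compounds go, the effect of a carboxylic acid or an amine in place of phenyl at this carbon also remains open.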